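This account rests on a few compounds, and the source may have more. Where it says the series, first, only, none or still open, it means among the compounds named here.

Compound 1 `CC(=O)Nc1ccc2oc(-c3ccccc3F)cc(=O)c2c1` and compound 2 `CC(=O)Nc1ccc2oc(-c3cccc(F)c3)cc(=O)c2c1` share one core, while compound 3 `COc1c(-c2ccccc2F)oc2ccc(N)cc2c1=O` and compound 4 `COc1c(-c2cccc(F)c2)oc2ccc(N)cc2c1=O` share another; how the two cores differ is not broken down here. In an ADME assay on MT4 cells (Homo sapiens) for cytotoxicity, read by MTT assay, with a stated time of 4 days (on this read-out lower numbers stand for higher toxicity in this test and higher numbers for lower toxicity in this test), compound 1 gives 205000 nM, compound 2 gives 240000 nM, and compound 3 gives 234000 nM. The change from compound 1 to compound 2 is 3-fluorophenyl in place of 2-fluorophenyl on an aromatic carbon, and it made a 1.2-fold higher number from compound 1 to compound 2 (0.07 log units; within the scatter). Compound 4 arises from compound 3 by 3-fluorophenyl in place of 2-fluorophenyl on an aromatic carbon; the place in compound 3 is also ortho to a methoxy group, so this is the same kind of change rather than the same change. Because the step of a 1.2-fold higher number from compound 1 to compound 2 (0.07 log units; within the scatter) stayed within the scatter, the expected step for compound 4 is a 1.1-fold higher number from compound 3 to compound 4 (0.05 log units; within the scatter). Compound 4 is thus estimated at 260000 nM, between 150000 nM and 450000 nM.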

Compound 4, half-maximal cytotoxic concentration: 113000 nM
The estimate for compound 4 lay 2.3-fold (0.36 log units) above the measured number, outside the stated range (below it).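

In this assay, the move from 2-fluorophenyl to 3-fluorophenyl gave a 2.1-fold lower number from compound 3 to compound 4 (0.32 log units; beyond the scatter), whereas the same change on the core of compound 1 stayed within the scatter. Set side by side, the two steps cannot be told apart: the same change on two cores in this assay, a 1.2-fold higher number (0.07 log units; within the scatter) from compound 1 to compound 2 and a 2.1-fold lower number (0.32 log units; beyond the scatter) from compound 3 to compound 4, 2.4-fold (0.38 log units) apart, within the scatter of two such steps. For the compounds shown here, the data therefore do not show that the core alters the effect of this change, but with only one pair on each core they do not show that it carries over unchanged either.

The compounds shown leave open whether a chlorine atom or a nitrile in place of the fluorine would behave in the same way on both cores. They also leave open whether any single difference between the two cores bears on the step.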